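Ring-Fused Group Replaces the Fluorinated Phenyl on the Urea

This account rests on a few compounds, and the source may have more. Where it says the series, first, only, none or still open, it means among the compounds named here.

Measured compounds:
compound 1 `CC(C(=O)NCc1ccc(C(F)(F)F)cc1N1CCC(Cc2ccccc2)(N(C)C)CC1)c1ccc(NS(C)(=O)=O)c(F)c1`: 3.79 nM
compound 2 `CN(C)C1(Cc2ccccc2)CCN(c2cc(C(F)(F)F)ccc2CNC(=O)Nc2ccc(CNS(C)(=O)=O)c(F)c2)CC1`: 16.4 nM
compound 3 `CN(C)C1(Cc2ccccc2)CCN(c2cc(C(F)(F)F)ccc2CNC(=O)Nc2ccc(CO)c(F)c2)CC1`: 27.9 nM

In an assay on CHO cells for displacement of a labelled ligand from transient receptor potential cation channel subfamily V member 1 (Homo sapiens), read by scintillation counting, with a stated time of 60 min (on this read-out higher numbers stand for weaker inhibition and lower numbers for stronger inhibition), compound 3 gives 27.9 nM, the highest of the three numbers. Going by the values given here, the single recorded step is a 1.7-fold higher number from compound 2 to compound 3 (0.23 log units; within the scatter), a change within the scatter. Compound 1, in this assay at 3.79 nM, lies well apart from compound 3.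

Compound 4 `CN(C)C1(Cc2ccccc2)CCN(c2cc(C(F)(F)F)ccc2CNC(=O)Nc2cccc3[nH]c(=O)ccc23)CC1` differs from compound 3 by a group of 11 heavy atoms (9 carbon, 1 nitrogen, 1 oxygen; one six-membered aromatic ring of carbon only, one six-membered aromatic ring with 1 hetero atom) in place of a group of 9 heavy atoms (7 carbon, 1 oxygen, 1 fluorine; one six-membered aromatic ring of carbon only), on an amide-type nitrogen. Among the compounds with values here, none of the measured steps concerns this exchange; the one step available touches a different part of the molecule and was itself small. Within the data shown here, with no direct precedent, the step is expected to be modest, and the estimate for compound 4 is therefore drawn around compound 3 with wide bounds: compound 4 is estimated at 20 nM, spanning 5 nM to 80 nM. The implied step a 1.4-fold lower number from compound 3 to compound 4 (0.14 log units; within the scatter) is an expectation only.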

Compound 4, inhibition constant: 1.67 nM
Beside the measured number, compound 4's estimate is 12-fold (1.08 log units) above it; the measured number lies below the stated range.
By their numbers in this assay, from the lowest: compound 4; then compound 1; then compounds 2 and 3 (each within the scatter of the next).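

In this assay, putting the new ring-fused group on an amide-type nitrogen in place of 3-fluoro-4-(hydroxymethyl)phenyl gives a 17-fold lower number from compound 3 to compound 4 (1.22 log units; beyond the scatter). This position therefore responds strongly to the change, unlike the earlier exchange of methanesulfonamido for hydroxy, a 1.7-fold higher number from compound 2 to compound 3 (0.23 log units; within the scatter). No available evidence accounts for this step.

The compounds shown leave open which part of the entering group carries the step. They also leave open whether a methoxy group or a carboxylic acid on that group would preserve it.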